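Swapping the aryl ring on the hydrazone arm: compound 3

A few compounds are considered here, and "the series" means these few. Any claim that something is new, unique, unknown or untested is made for them only; others in the source may bear on it.

Compound 1 `O=C(CSc1nnc(-c2ccncc2)o1)N/N=C/c1ccc(Cl)cc1` is tested in an ADME assay on NIH3T3 cells (Mus musculus) for cytotoxicity, read by MTT assay, with a stated time of 24 h (on this read-out lower numbers stand for stronger inhibition and higher numbers for weaker inhibition), where compound 1 gives 181000 nM, the lowest of the two numbers seen; compound 2 `O=C(CSc1nnc(-c2ccncc2)o1)N/N=C/c1cccc(F)c1` gives 205000 nM, and the step of a 1.1-fold higher number from compound 1 to compound 2 (0.05 log units; within the scatter) lies within the scatter. Compound 3 `O=C(CSc1nnc(-c2ccncc2)o1)N/N=C/c1cccs1` is not yet measured. It differs from compound 1 by thiophen-2-yl in place of 4-chlorophenyl on a carbon with a double bond to nitrogen. Among the compounds with values here, no measured step swaps in a thiophen-2-yl ring, so the only guide is that the one measured ring change left the number essentially unmoved. The step of a 1.0-fold higher number from compound 1 to compound 3 (0.02 log units; within the scatter) is therefore expected to stay within the scatter, and compound 3 is estimated at 190000 nM, with a range from 90000 nM to 400000 nM.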

Compound 3, half-maximal inhibitory concentration: 189000 nM
The estimate for compound 3 lay 1.0-fold (0.00 log units) above the measured number; the range from low to high includes it.
By their numbers in this assay, from the lowest: compounds 1, 3 and 2 (each within the scatter of the next).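

In this assay, the step of a 1.0-fold higher number from compound 1 to compound 3 (0.02 log units; within the scatter) and the step of a 1.1-fold lower number from compound 2 to compound 3 (0.04 log units; within the scatter) show that this position also accepts a five-membered aromatic ring with 1 hetero atom, not only a halogen-bearing phenyl ring, without a change beyond the scatter. The carbon with a double bond to nitrogen has thus carried three different aryl groups with no separation among their numbers. No evidence is available to explain this result. The compounds shown leave open whether an amine, a carboxylic acid or a longer chain at this position would move the number beyond the scatter.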